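Para-substituent swap on the arylidene thiosemicarbazide series

This account rests on a few compounds, and the source may have more. Where it says the series, first, only, none or still open, it means among the compounds named here.

Measured so far in a functional assay on the whole organism with Mus musculus as the target, with a stated time of 0.5 h; on this read-out higher numbers stand for an effect only at larger amounts of compound and lower numbers for an effect already at smaller amounts:
- compound 1, `Fc1ccc(/C=N/NC(=S)Nc2nc3ccc(Cl)cc3s2)cc1`: 100 mg/kg
- compound 2, `Oc1ccc(/C=N/NC(=S)Nc2nc3ccc(Cl)cc3s2)cc1`: 100 mg/kg

Among the measured compounds shown here, compound 2 stands level with compound 1 at the digits reported; the only step measured so far, hydroxy in place of fluoro on an aromatic carbon, gave no change at the digits printed from compound 1 to compound 2 (within the scatter). For the measured compounds named here, no other step is available.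

Compound 3, `O=[N+]([O-])c1ccc(/C=N/NC(=S)Nc2nc3ccc(Cl)cc3s2)cc1`, is the next member to be measured. It differs from compound 2 by nitro in place of hydroxy on an aromatic carbon. Going by the values given here, the single measured step bears on it only indirectly: it exchanged one substituent for another at the same aromatic carbon and left the minimum effective dose unchanged within the scatter, so a second exchange at that carbon is, on the present evidence, expected to do the same. Among the compounds with values here, no step with nitro has been measured, so the expectation rests on that one step alone.

The step from compound 2 to compound 3 is therefore expected to be no change at the digits printed from compound 2 to compound 3 (within the scatter). Compound 3 is estimated at 100 mg/kg, within a range of 50 mg/kg to 200 mg/kg.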

Compound 3, minimum effective dose: 300 mg/kg
For compound 3 the middle estimate is 3.0-fold (0.48 log units) below the measured one; measured number above the stated range.
By their numbers in this assay, from the lowest: compounds 1 and 2 (each within the scatter of the next); then compound 3.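

Working from this assay, the aromatic carbon para to a large group no longer looks indifferent to what it carries: nitro in place of hydroxy gives a 3.0-fold higher number from compound 2 to compound 3 (0.48 log units; beyond the scatter), while the earlier exchange of fluoro for hydroxy showed no change beyond the scatter. Nitro in place of fluoro gives a 3.0-fold higher number from compound 1 to compound 3 (0.48 log units; beyond the scatter), so both steps into nitro point the same way, toward a larger dose for an effect, and both are modest in size; this holds for these three compounds only and is not yet a rule for the series. No measurement at hand accounts for the shift.

Going by these compounds, whether an amine, a carboxylic acid or a methoxy group at this carbon would sit level with compound 1 and compound 2 or move with compound 3 remains open. Also open, on these data alone, is whether nitro in place of hydroxy would give a step of the same size on a core other than the one shared here, or with the substituent on another carbon of the same aromatic ring.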